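A substituted amide-type nitrogen on compound 1

A few compounds are considered here, and "the series" means these few. Any claim that something is new, unique, unknown or untested is made for them only; others in the source may bear on it.

- Compound 1 (`C=CC(=O)Nc1nc(-c2ccccc2O)cs1`) gives > 30000 nM as a limit of the assay
- Compound 2 (`C=CC(=O)Nc1nc(-c2ccccc2F)cs1`) gives 20400 nM as a measured number
- Compound 3 (`C=CC(=O)N(Cc1cc(C)no1)c1nc(-c2ccccc2O)cs1`) has no value yet

In a functional assay on HCT-116 cells (Homo sapiens) for antiproliferative activity, read by MTT assay, with a stated time of 72 h (on this read-out higher numbers stand for weaker inhibition and lower numbers for stronger inhibition), compound 1 gives > 30000 nM as a limit and not as a number. Compound 1 stands at the limit of > 30000 nM in this assay, at which 1 of the 2 values shown sits, and no finer rank can be given to it. Compound 3 differs from compound 1 by (3-methyl-1,2-oxazol-5-yl)methyl in place of hydrogen on an amide-type nitrogen and keeps the rest of the core of compound 1. Going by the values given here, the only measured step is an at least 1.4-fold lower number from compound 1 to compound 2 (0.16 log units; that floor lies within the scatter) and it concerns fluoro in place of hydroxy on an aromatic carbon, not that nitrogen. It therefore gives no measured size for this change, and its floor lies within the scatter. A modest move to a lower number is expected, though with little support and a real chance that compound 3 also stops at a limit. In this assay the expected size is an at least 2.5-fold lower number from compound 1 to compound 3 (0.39 log units; beyond the scatter) and it remains a rough estimate. For compound 3 the estimated value is 12000 nM with an expected range from 2500 nM to 45000 nM in this assay once it is measured.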

Compound 3, half-maximal inhibitory concentration: > 30000 nM
Compound 3: no number, only a limit; the forecaster's own chance of this, stated with the estimate: 30%; middle value at least 2.5-fold (0.39 log units) from the limit.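

In this assay compound 3 gives > 30000 nM, a limit of the assay and not a number. Going by these compounds alone, compound 1 also stops at a limit, so no step from compound 1 to compound 3 can be read. The compounds shown leave open whether (3-methyl-1,2-oxazol-5-yl)methyl in place of hydrogen on the amide-type nitrogen changes the read-out at all.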